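The source may hold more compounds than are shown below. What is called first, only, known or untested is meant among the compounds shown, and "the series" means these compounds.

Compound 1 `Nc1sc2c(c1-c1nc3cc(Cl)ccc3s1)CCC2`: 59.1 ug/mL
Compound 2 `Clc1ccc(/C=N/c2sc3c(c2-c2nc4ccccc4s2)CCCC3)cc1`: 367 ug/mL
Compound 3 `C(=C/c1ccccc1)\C=N\c1sc2c(c1-c1nc3ccccc3s1)CCCC2`: 207 ug/mL

In an ADME assay on cells (Rhabdomyosarcoma cell, Homo sapiens) for cytotoxicity, read by MTT assay, with a stated time of 72 h (a lower number here means that less compound is tolerated, a higher number that more compound is tolerated), compound 1 stands lowest of the three; compound 3 sits well above it, and compound 2 higher still. Compound 4 `Oc1ccccc1/C=N/c1sc2c(c1-c1nc3cc(Cl)ccc3s1)CCC2` is not yet measured. It differs from compound 1 in one place: a group of 9 heavy atoms (7 carbon, 1 nitrogen, 1 oxygen; one six-membered aromatic ring of carbon only) in place of one nitrogen atom, on an aromatic carbon. Going by the values given here, no measured step covers this change directly. Among the compounds with values here, the only step available, a 1.8-fold lower number from compound 2 to compound 3 (0.25 log units; within the scatter), swaps one group on a carbon with a double bond to nitrogen and lies within the scatter, so it says little on its own. Still, compounds 2 and 3, which both carry a group of the same kind in place of the amino group, show higher numbers than compound 1, though their cores also differ from it. Compound 4 is therefore expected to give a higher number, a 3.0-fold higher number from compound 1 to compound 4 (0.48 log units; beyond the scatter), with an estimate of 180 ug/mL and a range of 70 ug/mL to 450 ug/mL.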

Compound 4, half-maximal cytotoxic concentration: 269 ug/mL
The estimate for compound 4 lay 1.5-fold (0.17 log units) below the measured number; measured number inside the range.
By their numbers in this assay, from the lowest: compound 1; then compounds 3, 4 and 2 (each within the scatter of the next).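

In this assay, going by these compounds alone, the step of a 4.6-fold higher number from compound 1 to compound 4 (0.66 log units; beyond the scatter) is the first comparison made on one unchanged core, and it comes with the large ring-bearing group in place of the amino group on this aromatic carbon. Compounds 2 and 3 could only hint at such a shift, as their cores differ from that of compound 1. No measurement shown here accounts for the change. From the compounds shown here alone, it remains open which part of the entering group carries the step, the aromatic ring, its oxygen or the double bond to nitrogen. Going by these compounds, it is also open whether a smaller group, such as methylamino or an acetyl amide, would give a similar number.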